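The source may report more compounds than this note shows. Statements on the series, on what has been measured and on what is new or still open speak of the compounds shown alone.

Measured compounds:
compound 1 `CCN(C(=O)C1CCN(S(=O)(=O)c2ccc3cn[nH]c3c2)CC1)[C@H](C)c1ccccc1`, 87%
compound 2 `CCN(Cc1ccccc1F)C(=O)C1CCN(S(=O)(=O)c2ccc3cn[nH]c3c2)CC1`, 84%

In a functional assay on CHO cells for positive allosteric modulation of muscarinic acetylcholine receptor M5 (Homo sapiens), read by calcium flux (on this read-out higher numbers stand for larger maximal responses and lower numbers for smaller maximal responses), compound 1 reaches 87% and compound 2 reaches 84%; the step of a number 3 percentage points lower from compound 1 to compound 2 (within the scatter) exchanges 2-fluorobenzyl for 1-phenylethyl on an amide-type nitrogen and stays within the scatter. Compound 2 therefore holds the lower of the two numbers, with compound 1 within the scatter of it, so neither can be called larger or smaller in maximal response.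

Compound 3 `CCN(Cc1cccc(OC)c1)C(=O)C1CCN(S(=O)(=O)c2ccc3cn[nH]c3c2)CC1` is not yet measured. It differs from compound 2 as follows: 3-methoxyphenyl in place of 2-fluorophenyl on a saturated chain carbon bound to an amide-type nitrogen

Among the measured compounds shown here, no measured step touches this exchange: the only step available, from compound 1 to compound 2, changes the group on the amide-type nitrogen itself rather than the substituent on the benzyl ring, and its size in this assay lies within the scatter. For the measured compounds named here, the one comparison in hand shows that varying the group on that nitrogen leaves the maximal response essentially unchanged, so for compound 3 the expected step of a number 2 percentage points lower from compound 2 to compound 3 (within the scatter) is none beyond the scatter.

For compound 3 in this assay the estimate is 82%, with an expected range from 65% to 96%.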

Compound 3, largest response reached (reported as percent of maximum), in percent of the reference or control that the assay uses: 85%
Compound 3: middle estimate off by 3 percentage points, on the low side; measured number inside the range.
By their numbers in this assay, from the lowest: compounds 2, 3 and 1 (each within the scatter of the next).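

Working notes on the series: in this assay the exchange of 2-fluorophenyl for 3-methoxyphenyl on a saturated chain carbon bound to an amide-type nitrogen gives a number 1 percentage points higher from compound 2 to compound 3 (within the scatter) and is the first measured change to the substituent on the benzyl ring itself, so at this place neither group can be called better than the other. The comparison with the branched group gives a number 2 percentage points lower from compound 1 to compound 3 (within the scatter) for 3-methoxybenzyl in place of 1-phenylethyl on an amide-type nitrogen, and all three groups now shown at this nitrogen therefore stay within the scatter of one another on maximal response, with no compound among the three going against that reading. No measurement at hand offers an explanation for this lack of separation.

The compounds shown leave open whether a substituent of a different kind on the benzyl ring, such as a carboxylic acid or an amine, would move the maximal response beyond the scatter. Also open, going by these compounds, is whether a propyl chain in place of the ethyl group on the amide-type nitrogen, or a cyclohexylmethyl group in place of the benzyl group, would do so.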